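The compounds below may be only part of what the source reports. "The series", "measured", "known", "first", "only" and "open" are said of these compounds alone.

Compound 3 `CCc1cccc2c(OC)c(-c3occ(C)c3CBr)ccc12` gives 4.6 ug/mL in a functional assay on ZR-75-1 cells (Homo sapiens) for cytotoxicity, read by MTT assay, with a stated time of 72 h; a lower number here means that less compound is needed, a higher number that more compound is needed for the effect. Compound 1 `CCc1cccc2c(OC)c(-c3occ(C)c3C(=S)OC)ccc12` gives 5.8 ug/mL in this assay, and compound 2 `CCOCc1c(C)coc1-c1ccc2c(CC)cccc2c1OC` gives 9.1 ug/mL; the gaps are a 1.3-fold lower number from compound 1 to compound 3 (0.10 log units; within the scatter) and a 2.0-fold lower number from compound 2 to compound 3 (0.30 log units; within the scatter), so the three compounds stand together on these numbers. Compound 4 `CCc1cccc2c(OC)c(-c3occ(C)c3COC(C)=O)ccc12` differs from compound 3 by acetoxy in place of bromo on a saturated chain carbon bound to an aromatic carbon. The step that bears most on this exchange is a 2.0-fold lower number from compound 2 to compound 3 (0.30 log units; within the scatter), a swap of groups at the same saturated chain carbon that stayed within the scatter, as did a 1.6-fold higher number from compound 1 to compound 2 (0.20 log units; within the scatter) at the aromatic carbon. Compound 4 is therefore expected to show no step beyond the scatter, a 1.2-fold higher number from compound 3 to compound 4 (0.08 log units; within the scatter), in this assay. Compound 4 is estimated at 5.5 ug/mL, with a range from 2.7 ug/mL to 11 ug/mL.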

Compound 4, concentration for half-maximal effect: 3.5 ug/mL
Compound 4: the middle estimate sits 1.6-fold (0.20 log units) above what was measured; measured number inside the range.
By their numbers in this assay, from the lowest: compounds 4, 3, 1 and 2 (each within the scatter of the next, the first and the last beyond it).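

Acetoxy on this saturated chain carbon stands with bromo in this assay (a 1.3-fold lower number from compound 3 to compound 4 (0.12 log units; within the scatter)) and with the group carried by compound 1 (a 1.7-fold lower number from compound 1 to compound 4 (0.22 log units; within the scatter)). Among these compounds, what is new is the first step beyond the scatter at this position, a modest one, with acetyl in place of ethyl on the oxygen (a 2.6-fold lower number from compound 2 to compound 4 (0.41 log units; beyond the scatter)). No measurement shown here accounts for that step. The compounds shown leave open how an amine or a carboxylic acid on this chain carbon would read. They also leave open whether a longer chain on the acetyl carbonyl would keep the number of compound 4.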